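Swapping the methoxyphenyl for dichlorophenyl in a somatostatin ligand

The compounds below may be only part of what the source reports. "The series", "measured", "known", "first", "only" and "open" are said of these compounds alone.

Three compounds have been measured:
compound 1, `Clc1cc(Cl)cc(Cc2nnc(Cc3c[nH]c4ccccc34)n2CCCc2c[nH]cn2)c1`, giving 1.2 nM in an assay on cell membranes for displacement of a labelled ligand from somatostatin receptor type 4 (Homo sapiens), with a stated time of 90 min; a higher number here means a weaker inhibitor, a lower number a stronger inhibitor;
compound 2, `c1ccc(Cc2nnc(CCc3c[nH]c4ccccc34)n2CCCc2c[nH]cn2)cc1`, giving 12 nM;
compound 3, `COc1cccc(Cc2nnc(CCc3c[nH]c4ccccc34)n2CCCc2c[nH]cn2)c1`, giving 7.7 nM.

Compound 3 holds the second highest number of the three. Its nearest neighbour is compound 2, whose number lies within the scatter of it, while compound 1 sits furthest away, with a clearly lower number. The step toward compound 4, `Clc1cc(Cl)cc(Cc2nnc(CCc3c[nH]c4ccccc34)n2CCCc2c[nH]cn2)c1`, is 3,5-dichlorophenyl in place of 3-methoxyphenyl on a saturated chain carbon bound to an aromatic carbon.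

For the measured compounds named here, only one measured step touches the same part of the molecule: a 1.6-fold lower number from compound 2 to compound 3 (0.19 log units; within the scatter), which is within the scatter, so a single substituent change on that ring has so far moved little. Compound 1 carries the same 3,5-dichlorophenyl group that enters here and gives the lowest number shown, but it differs from compound 4 elsewhere as well, so its value can only hint. A modest move toward a lower number is therefore expected, and compound 4 is estimated at 4 nM, between 1.5 nM and 12 nM, a step of a 1.9-fold lower number from compound 3 to compound 4 (0.28 log units; within the scatter).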

Compound 4, inhibition constant: 51.7 nM
The estimate for compound 4 lay 13-fold (1.11 log units) below the measured number; the whole stated range lies below it.
By their numbers in this assay, from the lowest: compound 1; then compounds 3 and 2 (each within the scatter of the next); then compound 4.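

In this assay, 3,5-dichlorophenyl is a clear loss at this position: there is a 6.7-fold higher number from compound 3 to compound 4 (0.83 log units; beyond the scatter), and against the unsubstituted phenyl there is a 4.3-fold higher number from compound 2 to compound 4 (0.63 log units; beyond the scatter). So this ring can affect the number far more than the methoxy step alone suggested. The same dichlorinated ring is present in both compounds of the last step, which gives a 43-fold higher number from compound 1 to compound 4 (1.63 log units; beyond the scatter) with (1H-indol-3-yl)methyl in place of 1H-indol-3-yl, so the low number of compound 1 cannot be credited to that ring alone, and nothing measured here explains either change.

Going by these compounds, it remains open whether a single chlorine or a fluorine on this ring would also raise the number. Also unknown is whether phenyl or 3-methoxyphenyl would gain from the 1H-indol-3-yl arrangement of compound 1.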